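The source may report more compounds than this note shows. Statements on the series, on what has been measured and on what is new or still open speak of the compounds shown alone.

Measured so far:
- compound 1, `Nc1cc(N)c2nc(-c3ccccc3)c(Oc3ccc(Cl)c(Cl)c3)nc2c1`: in a functional assay on NCI-H522 cells (Homo sapiens) for inhibition, read by sulforhodamine B assay, with a stated time of 48 h (on this read-out lower numbers stand for higher toxicity in this test and higher numbers for lower toxicity in this test), compound 1 gives < 100000 nM, which is a limit of the assay and not a number.
- compound 2, `COc1ccc(CNc2nc3cc(N)cc(N)c3nc2-c2ccccc2)cc1OC`: compound 2 gives 63100 nM.

For the measured compounds named here, compound 2 therefore holds the only actual number in this assay; the other entry sits at the limit of < 100000 nM in this assay, at which 1 of the 2 values shown sits. Going by the values given here, the two compounds share a core and differ in the group attached to it, but no step between them is worked out, so the pair shows only these two values.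

Compound 3, `Nc1cc(N)c2nc(-c3ccccc3)c(NCc3ccc(F)cc3)nc2c1`, has not yet been measured. It differs from compound 2 in one place: 4-fluorophenyl in place of 3,4-dimethoxyphenyl on a saturated chain carbon bound to a nitrogen on an aromatic ring. Among the compounds with values here, with no measured step to lean on, the change from one benzyl-type group to another is expected to move the result little, and the estimated step of a 1.3-fold lower number from compound 2 to compound 3 (0.10 log units; within the scatter) is expected to stay within the usual scatter. Compound 3 is thus expected to give about 50000 nM, within a range from 15000 nM to 150000 nM.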

Compound 3, concentration lethal to 50% of the cells: < 100000 nM
Compound 3: only a limit was reported (the forecaster's own chance of this, stated with the estimate: 30%); the middle value does not contradict the limit.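

In this assay compound 3 gives < 100000 nM, which is a limit of the assay and not a number. For the compounds shown here, no step from compound 1 or compound 2 to compound 3 can therefore be read. Whether 4-fluorophenyl in place of 3,4-dimethoxyphenyl shifts the result at all stays open, because most entries are limits: the limit of < 100000 nM in this assay, at which 2 of the 3 values shown sit.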